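A few compounds are considered here, and "the series" means these few. Any claim that something is new, unique, unknown or untested is made for them only; others in the source may bear on it.

In an ADME assay on L6 cells (Rattus norvegicus) for cytotoxicity, read by resazurin assay, with a stated time of 72 h (on this read-out higher numbers stand for weaker inhibition and lower numbers for stronger inhibition), the three measured compounds sit close together. Compound 1 `OC(c1ccc(Cl)cc1)(c1ccc(Br)cc1)c1cncnc1` gives 58700 nM, compound 2 `Cc1ccccc1C(O)(c1ccc(Cl)cc1)c1cccnc1` gives 82000 nM, and compound 3 `OC(c1ccc(Cl)cc1)(c1cccnc1)c1ccccc1Br` gives 55200 nM, so compound 3 stands within the scatter of both others. Compound 4 `OC(c1ccc(Cl)cc1)(c1cccnc1)c1cncnc1` differs from compound 3 by a single swap: pyrimidin-5-yl in place of 2-bromophenyl on a saturated chain carbon bound to two aromatic carbons and an oxygen on a saturated carbon. In words, pyrimidin-5-yl takes the place of 2-bromophenyl on a saturated chain carbon bound to two aromatic carbons and an oxygen on a saturated carbon.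

Going by the values given here, the only measured step, a 1.5-fold lower number from compound 2 to compound 3 (0.17 log units; within the scatter), concerns a different exchange and is a weak guide. Compound 1 already carries pyrimidin-5-yl and gives 58700 nM, but it also holds a bromine, which compound 4 lacks. No direct comparison exists for this swap, so only a small move towards a higher number is expected, and the estimated step is a 1.8-fold higher number from compound 3 to compound 4 (0.26 log units; within the scatter). For compound 4 the estimated value is 100000 nM, with an expected range from 50000 nM to 220000 nM.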

Compound 4, half-maximal inhibitory concentration: > 100000 nM
Compound 4 ended at the assay's limit (the forecaster's own chance of this, stated with the estimate: 20%); the middle value sits exactly at the limit.
By their numbers in this assay, from the lowest: compounds 3, 1 and 2 (each within the scatter of the next). At a limit, above all of these: compound 4.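

Compound 4 sits at a limit of this assay, not at a measured number: the limit of > 100000 nM in this assay, at which 1 of the 4 values shown sits.

With pyrimidin-5-yl in place of 2-bromophenyl there is an at least 1.8-fold higher number from compound 3 to compound 4 (0.25 log units; that floor lies within the scatter), with pyrimidin-5-yl in place of 2-methylphenyl there is an at least 1.2-fold higher number from compound 2 to compound 4 (0.08 log units; that floor lies within the scatter), and with pyridin-3-yl in place of 4-bromophenyl there is an at least 1.7-fold higher number from compound 1 to compound 4 (0.23 log units; that floor lies within the scatter). Compound 4 is the first compound shown in which this saturated chain carbon carries no bromophenyl or methylphenyl group, yet each of these floors lies within the scatter, so no step is shown to be a real change.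

From the compounds shown here alone, how far the true value of compound 4 lies past the limit stays open. It is also unknown whether losing the bromine or gaining the ring nitrogens matters more, and a plain phenyl or an aminomethylphenyl group at this carbon would help separate the two.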